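A Methoxy Group Replaces Chlorine on the Amide Aryl Ring

A few compounds are considered here, and "the series" means these few. Any claim that something is new, unique, unknown or untested is made for them only; others in the source may bear on it.

Of the compounds shown here, three sharing one core have been tested in a functional assay on HCT-116 cells (Homo sapiens) for antiproliferative activity, read by MTT assay, with a stated time of 48 h; on this read-out higher numbers stand for weaker inhibition and lower numbers for stronger inhibition. Compound 1 `O=C(Nc1cc(Sc2ncn[nH]2)c(O)c2ccccc12)c1ccc2ccccc2c1` carries a naphthalen-2-yl group on the carbonyl carbon, and in this assay compound 1 reaches only the limit > 100000 nM. Compound 2 `O=C(Nc1cc(Sc2ncn[nH]2)c(O)c2ccccc12)c1cccc(Cl)c1`, with a 3-chlorophenyl group, also gives only the limit > 100000 nM. Among the compounds with values here, compound 3 `O=C(Nc1cc(Sc2ncn[nH]2)c(O)c2ccccc12)c1ccc(Cl)cc1`, bearing a 4-chlorophenyl group, is the only one with a measured number, 43300 nM. Within the data shown here, two measured steps bear on what follows: an at least 2.3-fold lower number from compound 2 to compound 3 (0.36 log units; beyond the scatter), and an at least 2.3-fold lower number from compound 1 to compound 3 (0.36 log units; beyond the scatter). Compound 4 `COc1cccc(C(=O)Nc2cc(Sc3ncn[nH]3)c(O)c3ccccc23)c1` differs from compound 3 by 3-methoxyphenyl in place of 4-chlorophenyl on a carbonyl carbon. The step from compound 3 to compound 4 is expected to raise the number, a 2.3-fold higher number from compound 3 to compound 4 (0.36 log units; beyond the scatter), because the other 3-substituted phenyl analogue sits at the limit of > 100000 nM in this assay, at which 2 of the 3 values shown sit. Compound 4 is estimated at 100000 nM, between 30000 nM and 300000 nM.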

Compound 4, half-maximal inhibitory concentration: > 100000 nM
Compound 4: no number, only a limit; the forecaster's own chance of this, stated with the estimate: 60%; the middle value lies on the limit itself.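

In this assay the change to 3-methoxyphenyl gives an at least 2.3-fold higher number from compound 3 to compound 4 (0.36 log units; beyond the scatter), so this group does not keep the modest activity seen with 4-chlorophenyl. The steps linking compound 4 to compound 1 and compound 2 cannot be read, since both ends of each are limits. Compound 4 gives only a limit, like the 3-chlorophenyl compound 2, and compound 3 remains the only one with a number: the limit of > 100000 nM in this assay, at which 3 of the 4 values shown sit.

Still open, as far as these compounds go, is whether 4-methoxyphenyl would match 4-chlorophenyl or fall to the limit. The effect of an amine or a carboxylic acid on this phenyl ring is also unknown.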